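Swapping trifluoromethyl for methyl in a cell tolerance test

This account rests on a few compounds, and the source may have more. Where it says the series, first, only, none or still open, it means among the compounds named here.

Within the data shown here, in an ADME assay on Vero 76 cells (Chlorocebus sabaeus) for cytotoxicity, read by MTT assay, with a stated time of 96 h (a higher number here means that more compound is tolerated, a lower number that less compound is tolerated), compound 2 `Cc1ccc(NCc2cn(-c3ccccc3)nc2-c2ccc(C(F)(F)F)cc2)cc1` gives 82000 nM, the only exact number so far. Compound 1 `Cc1ccc(NCc2cn(-c3ccccc3)nc2-c2ccc(Cl)cc2)cc1` gives > 100000 nM, which is a limit of the assay and not a number. Both compounds are tolerated by these cells up to high concentrations, so neither reading points to marked harm.

Compound 3 `Cc1ccc(NCc2cn(-c3ccccc3)nc2-c2ccc(C)cc2)cc1` differs from compound 2 in one place: methyl in place of trifluoromethyl on an aromatic carbon. Methyl takes the place of trifluoromethyl on an aromatic carbon, leaving the shared core untouched.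

Among the measured compounds shown here, only one measured step bears on this change: an at least 1.2-fold lower number from compound 1 to compound 2 (0.08 log units; that floor lies within the scatter), with trifluoromethyl in place of chloro on an aromatic carbon. That step is known only as a floor because of the limit of > 100000 nM in this assay, at which 1 of the 2 values shown sits. It is a comparable swap of one group for another, and its floor stays within the scatter, so it gives no reason to expect a real shift here.

The expected result is a 1.0-fold higher number from compound 2 to compound 3 (0.02 log units; within the scatter), which means no change beyond the scatter in either direction. Compound 3 is estimated at 85000 nM, with an expected range from 40000 nM to 100000 nM.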

Compound 3, half-maximal cytotoxic concentration: > 100000 nM
Compound 3 was reported as a limit (the forecaster's own chance of this, stated with the estimate: 45%); middle value at least 1.1-fold (0.07 log units) away from the limit.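

The swap from trifluoromethyl to methyl gives an at least 1.2-fold higher number from compound 2 to compound 3 (0.08 log units; that floor lies within the scatter), so in this assay this change on an aromatic carbon shows no shift that can be told apart from ordinary repeat variation. Among these compounds, compound 3 gives > 100000 nM, which is a limit of the assay and not a number, so methyl joins chloro as a second group at this position whose compound gives no exact reading, and compound 2 still holds the only exact number. The step between compound 1 and compound 3 cannot be read, and the methyl and chloro compounds cannot be ranked, because both readings are limits: the limit of > 100000 nM in this assay, at which 2 of the 3 values shown sit.

How far compound 1 and compound 3 lie beyond that limit stays unknown, so a real gap between them and compound 2 can be neither shown nor ruled out. Also open is whether this position stays this well tolerated with a quite different group on the same aromatic carbon, such as an amine, a carboxylic acid or a longer chain, since all three groups shown here carry no hydrogen-bond donors or charge of the kind those groups could bring.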